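From 4-methylphenyl to 3-methylphenyl at the assay limit

This account rests on a few compounds, and the source may have more. Where it says the series, first, only, none or still open, it means among the compounds named here.

Measured so far in a functional assay on ECV-304 cells (Homo sapiens) for cytotoxicity (a lower number here means a stronger inhibitor, a higher number a weaker inhibitor), each value being a limit of the assay:
Compound 1 `Cc1ccc(S(=O)(=O)NN2C(=S)S/C(=C\c3ccc(Cl)c(Cl)c3)C2O)cc1`: > 50000 nM
Compound 2 `Cc1ccc(/C=C2\SC(=S)N(NS(=O)(=O)c3ccccc3)C2=O)cc1`: > 50000 nM
Compound 3 `COc1ccc(S(=O)(=O)NN2C(=S)S/C(=C\c3ccc(Cl)c(Cl)c3)C2O)cc1`: > 50000 nM

Compound 2 gives no number in this assay, only the limit > 50000 nM. It shares that position with both other measured compounds, and the set as a whole shows (the limit of > 50000 nM in this assay, at which 3 of the 3 values shown sit).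

Compound 4 `Cc1cccc(/C=C2\SC(=S)N(NS(=O)(=O)c3ccccc3)C2=O)c1` has not yet been measured. It is an isomer of compound 2, and the difference between them is 3-methylphenyl in place of 4-methylphenyl on a double-bonded chain carbon bound to a double-bonded ring carbon. In words, it is 3-methylphenyl in place of 4-methylphenyl on a double-bonded chain carbon bound to a double-bonded ring carbon.

For the measured compounds named here, only one measured step exists, a step that the two limits leave unreadable from compound 1 to compound 3. That step is methoxy in place of methyl on an aromatic carbon, which is a different change, and it gives no size to carry over. Going by the values given here, no measured step shows a change of the kind that leads to compound 4.

Among the compounds with values here, the only guide is therefore compound 2, with its limit of > 50000 nM, so no step beyond the scatter is expected and no direction can be assigned. The estimated step is a number no higher from compound 2 to compound 4 (the limit leaves the size open). Most likely the assay will again report only a limit. For compound 4 the expected value is 50000 nM, with an estimated range from 20000 nM to 100000 nM.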

Compound 4, half-maximal inhibitory concentration: > 50000 nM
Compound 4: a limit, no number (the forecaster's own chance of this, stated with the estimate: 85%); the middle value lies on the limit itself.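

Compound 2 and compound 4 are both reported in this assay only as limits, so no step can be read between them. All the compounds shown sit at the same limit: the limit of > 50000 nM in this assay, at which 4 of the 4 values shown sit.

The compounds shown leave open whether 3-methylphenyl and 4-methylphenyl differ at all in this assay, and what number any of these compounds would give.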